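Bromo to methyl on the aromatic ring of compound 3

The source may hold more compounds than are shown below. What is called first, only, known or untested is meant among the compounds shown, and "the series" means these compounds.

Compound 3 `CN1CCCN(CCn2ccc3ccc(Br)cc32)CC1` gives 93% in an assay on HEK293 cells for binding affinity to 5-hydroxytryptamine receptor 7 (Homo sapiens), read by radioligand binding, tested at 1 uM (a higher number here means more inhibition at the concentration tested (going by the name of the read-out), a lower number less inhibition), the highest of the three numbers measured; compound 1 `Brc1ccc2ccn(CCN3CCNCC3)c2c1` at 61% is nearest and compound 2 `CC1CN(CCn2ccc3ccc(Br)cc32)CCN1` at 52% furthest, both gaps beyond the scatter. Within the data shown here, the only step measured between two compounds that differ in one place is a number 9 percentage points lower from compound 1 to compound 2 (within the scatter), a methyl in place of hydrogen on a saturated ring carbon.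

Compound 4 `Cc1ccc2ccn(CCN3CCCN(C)CC3)c2c1` is compound 3 with methyl in place of bromo on an aromatic carbon, on an aromatic carbon of a six-membered aromatic ring of carbon only. Among the measured compounds shown here, no measured step bears on this change: the one step known concerns a saturated ring carbon, not the aromatic ring, and was within the scatter. The direction of the change therefore cannot be read from the data, and the range is widened accordingly.

For compound 4 the expected value in this assay is 75%, in the range 45% to 95%. The step this estimate means, a number 18 percentage points lower from compound 3 to compound 4 (beyond the scatter), is expected as a modest loss of uncertain direction.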

Compound 4, a percentage reported as inhibition, at one concentration (the size of the read-out at that concentration, not a potency): 62%
Beside the measured number, compound 4's estimate is 13 percentage points above it; the measured number falls inside the stated range.
By their numbers in this assay, from the lowest: compounds 2, 1 and 4 (each within the scatter of the next); then compound 3.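

Among these compounds, the aromatic carbon is the first place where a one-place change moves the number beyond the scatter: in this assay, methyl in place of bromo gives a number 31 percentage points lower from compound 3 to compound 4 (beyond the scatter), and this step is large. Among the compounds shown here, the only earlier step, a number 9 percentage points lower from compound 1 to compound 2 (within the scatter), concerned a saturated ring carbon, so the aromatic ring now stands as the more sensitive of the two places measured, on this evidence alone. Bromo and methyl each count one heavy atom, with no hydrogen-bond donors or acceptors and no net charge, so these counts do not separate them, and nothing available explains the drop.

Going by these compounds, whether chloro, methoxy or a nitrile at this carbon would hold the number near that of compound 3 remains open. Also open, on these data alone, is whether the same change on compound 1 would give a step of similar size.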